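A few compounds are considered here, and "the series" means these few. Any claim that something is new, unique, unknown or untested is made for them only; others in the source may bear on it.

Compound 1 `O=C(O)COc1cccc(-c2[nH]ncc2-c2nc(-c3ccccc3)c(-c3ccccc3)o2)c1` gives 3200 nM
Compound 2 `Cn1cc(-c2nc(-c3ccccc3)c(-c3ccccc3)o2)c(-c2cccc(OCC(=O)O)c2)n1` gives 302 nM
Compound 3 `Cc1nc(-c2nc(-c3ccccc3)c(-c3ccccc3)o2)c(-c2cccc(OCC(=O)O)c2)o1` gives 36.6 nM

These values come from a functional assay for inhibition, with Homo sapiens as the target, at 37 degrees C, tested at 5.4 nM; a higher number here means a weaker inhibitor, a lower number a stronger inhibitor. Compound 1 has the highest of the three numbers, which makes it the weakest inhibitor of the set. Compound 4 `Cn1ncc(-c2nc(-c3ccccc3)c(-c3ccccc3)o2)c1-c1cccc(OCC(=O)O)c1` has not yet been measured. It differs from compound 1 by methyl in place of hydrogen on an aromatic nitrogen, with methyl in place of hydrogen on an aromatic nitrogen. Within the data shown here, no measured pair isolates this change, so the evidence is indirect. Compound 2, which also has methyl on an aromatic nitrogen, gives 302 nM, a lower number than that of compound 1. A drop beyond the scatter is therefore expected, and the estimated step is an 11-fold lower number from compound 1 to compound 4 (1.03 log units; beyond the scatter). For compound 4 the estimated value is 300 nM, with an expected range of 60 nM to 1500 nM.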

Compound 4, half-maximal inhibitory concentration: 337 nM
Beside the measured number, compound 4's estimate is 1.1-fold (0.05 log units) below it; the measured number falls inside the stated range.
By their numbers in this assay, from the lowest: compound 3; then compounds 2 and 4 (each within the scatter of the next); then compound 1.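

In this assay, methyl in place of hydrogen on this aromatic nitrogen can now be read directly, as a 9.5-fold lower number from compound 1 to compound 4 (0.98 log units; beyond the scatter), and this step lies beyond the scatter. A single carbon added on the nitrogen, next to the ring atom that bears a 3-(carboxymethoxy)phenyl group, is thus enough to give a stronger inhibitor. No measurement shown here explains the step. As far as these compounds go, whether an ethyl group or a longer chain on this nitrogen would give a lower or a higher number stays open, as does the effect of an acetyl group there.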